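The source may hold more compounds than are shown below. What is called first, only, known or untested is meant among the compounds shown, and "the series" means these compounds.

Compound 3 `CCOc1ccccc1Cc1cnc(N)nc1N` gives 24500 nM in an assay for inhibition of Dihydrofolate reductase (Gallus gallus) (a higher number here means a weaker inhibitor, a lower number a stronger inhibitor), the highest of the three numbers in hand. Its nearest neighbour is compound 2 `Nc1ncc(Cc2ccccc2Br)c(N)n1`, which gives 12300 nM; the step of a 2.0-fold higher number from compound 2 to compound 3 (0.30 log units; within the scatter) stays within the scatter. Compound 1 `Nc1ncc(Cc2ccccc2OCc2ccccc2)c(N)n1` gives 9120 nM. Compound 4 `NC(=O)COc1ccccc1Cc1cnc(N)nc1N` has not yet been measured; it differs from compound 3 by carbamoyl in place of methyl on a saturated chain carbon bound to an oxygen on an aromatic ring. Within the data shown here, the one earlier step at the same place is a 2.7-fold higher number from compound 1 to compound 3 (0.43 log units; beyond the scatter), where the larger group went with the lower number, but no measured pair shows a carbamoyl, so the direction carries little weight. Compound 4 is therefore expected to give about 15000 nM, between 5000 nM and 50000 nM, a step of a 1.6-fold lower number from compound 3 to compound 4 (0.21 log units; within the scatter) that may well lie within the scatter.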

Compound 4, inhibition constant: 33900 nM
Compound 4: middle estimate off by 2.3-fold (0.35 log units), on the low side, and the stated range covers the measured number.
By their numbers in this assay, from the lowest: compounds 1, 2, 3 and 4 (each within the scatter of the next, the first and the last beyond it).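

In this assay, carbamoyl in place of methyl on this saturated chain carbon gives a 1.4-fold higher number from compound 3 to compound 4 (0.14 log units; within the scatter) and so does not separate the two groups. Only against the other groups does a gap appear: the change from phenyl gives a 3.7-fold higher number from compound 1 to compound 4 (0.57 log units; beyond the scatter) and carbamoylmethoxy in place of bromo gives a 2.8-fold higher number from compound 2 to compound 4 (0.44 log units; beyond the scatter) on the aromatic carbon. No supporting evidence bears on what lies behind these steps. On these data alone, whether an amine or a carboxylic acid at this place, or a longer chain carrying the carbamoyl, would give a step beyond the scatter from compound 3 remains open.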